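Dropping the methoxy: expected plasma protein binding of compound 3

The compounds below may be only part of what the source reports. "The series", "measured", "known", "first", "only" and "open" are said of these compounds alone.

Measured so far:
- compound 1 `CCCS(=O)(=O)Nc1ccc(Cl)c(C(=O)Nc2cnc3[nH]ncc3c2)c1F`: 97.1%
- compound 2 `CCCS(=O)(=O)Nc1ccc(F)c(C(=O)Nc2cnc3[nH]nc(OC)c3c2)c1F`: 97.4%

In an ADME assay on a cell-free system (plasma, Mus musculus, strain CD-1) for protein binding, compound 2 gives 97.4%, and compound 1 gives 97.1%; the two values lie within the scatter of each other, so neither compound stands apart. Compound 3 `CCCS(=O)(=O)Nc1ccc(F)c(C(=O)Nc2cnc3[nH]ncc3c2)c1F` is not yet measured. It differs from compound 2 by hydrogen in place of methoxy on an aromatic carbon. Within the data shown here, with no measured step to lean on, only a small change in this assay is expected, if any, likely within the scatter. The estimated step a 1.2-fold higher unbound fraction from compound 2 to compound 3 (0.06 log units; within the scatter) is therefore near zero. Compound 3 is expected to give about 97%, in a range from 95.5% to 98.3%.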

Compound 3, plasma protein binding in the plasma assay: 87.1%
For compound 3 the middle estimate is 4.3-fold (0.63 log units) (unbound fraction) below the measured one; measured number outside the range, below it.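

In the plasma assay, hydrogen in place of methoxy gives a 5.0-fold higher unbound fraction from compound 2 to compound 3 (0.70 log units; beyond the scatter), and fluoro in place of chloro gives a 4.4-fold higher unbound fraction from compound 1 to compound 3 (0.65 log units; beyond the scatter). Compound 3 carries neither methoxy nor chloro and is the least bound, so either group alone goes with high binding, which the earlier pair could not show. In a physicochemical assay for solubility, read by HPLC, in phosphate buffer, with a stated time of 24 h, at pH 6.5 (a lower number here means a less soluble compound, a higher number a more soluble compound), compound 2 gives 4 ug/mL and compound 3 gives 80 ug/mL. Going by these compounds, whether an amine or an ethoxy group on this aromatic carbon would sit nearer compound 2 or compound 3 in both read-outs stays open.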